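This account rests on a few compounds, and the source may have more. Where it says the series, first, only, none or still open, it means among the compounds named here.

Compounds measured so far:
- compound 1, `COc1cccc(C(=O)Nc2cccc(-c3oc4cc(-c5ccc(F)cc5)ccc4c(=O)c3O)c2)c1`, 15300 nM
- compound 2, `Cc1cccc(C(=O)Nc2cccc(-c3oc4cc(-c5ccc(F)cc5)ccc4c(=O)c3O)c2)c1`, 7850 nM
- compound 3, `COc1cc(OC)cc(C(=O)Nc2cccc(-c3oc4cc(-c5ccc(F)cc5)ccc4c(=O)c3O)c2)c1`, 3470 nM

In a functional assay on MCF7 cells (Homo sapiens) for antiproliferative activity, read by CCK-8 assay, with a stated time of 72 h (on this read-out higher numbers stand for weaker inhibition and lower numbers for stronger inhibition), compound 3 gives the lowest number of the three. Its nearest neighbour is compound 2, with a 2.3-fold lower number from compound 2 to compound 3 (0.35 log units; beyond the scatter), and the furthest is compound 1, with a 4.4-fold lower number from compound 1 to compound 3 (0.64 log units; beyond the scatter); both of these steps lie beyond the scatter, so compound 3 stands as the most potent of the measured set. Between compound 1 and compound 2 the step is a 1.9-fold lower number from compound 1 to compound 2 (0.29 log units; within the scatter), within the scatter.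

Compound 4, `O=C(Nc1cccc(-c2oc3cc(-c4ccc(F)cc4)ccc3c(=O)c2O)c1)c1ccc(-c2ccccc2)cc1`, differs from compound 3 in one place: 4-phenylphenyl in place of 3,5-dimethoxyphenyl on a carbonyl carbon. Among the compounds with values here, none of the measured steps touches a 4-phenylphenyl group. The two steps that bear on the amide aryl group, from compound 1 to compound 3 and from compound 2 to compound 3, both end at the 3,5-dimethoxyphenyl of compound 3, and both point to that group carrying the strongest inhibition seen so far. The new change removes it in favour of a group with no hydrogen-bond acceptors and a second aromatic ring, for which nothing here gives a direction. Compound 4 is therefore expected to show a step of a 1.4-fold higher number from compound 3 to compound 4 (0.16 log units; within the scatter), which is a modest move toward a higher number, with wide uncertainty. The estimate for compound 4 in this assay is 5000 nM, with a range from 1500 nM to 17000 nM.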

Compound 4, half-maximal inhibitory concentration: 38500 nM
For compound 4 the middle estimate is 7.7-fold (0.89 log units) below the measured one; measured number outside the range, above it.
By their numbers in this assay, from the lowest: compound 3; then compounds 2 and 1 (each within the scatter of the next); then compound 4.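

In this assay, within the data shown here, the group on the carbonyl carbon proved able to move the number much further than the earlier compounds showed: 4-phenylphenyl in place of 3,5-dimethoxyphenyl gives an 11-fold higher number from compound 3 to compound 4 (1.05 log units; beyond the scatter). The same group also falls behind the 3-methylphenyl and 3-methoxyphenyl groups, with a 4.9-fold higher number from compound 2 to compound 4 (0.69 log units; beyond the scatter) and a 2.5-fold higher number from compound 1 to compound 4 (0.40 log units; beyond the scatter), so compound 4 is the weakest of the four, and each of its steps lies beyond the scatter. The earlier compounds had shown only that this position responds to changes among groups with one six-membered aromatic ring, while this result shows that a second such ring in the 4-phenylphenyl group goes with weaker inhibition here, although no measurement at hand accounts for that.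

The compounds shown leave open whether the second ring itself, its place on the first ring, or the absence of the methoxy groups sets this result apart, since all of these change together between compound 3 and compound 4. They also leave open how this position would respond to a pyridine ring, a morpholine or a carboxylic acid on the amide aryl group.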